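Adding a Chloro Group Back onto the Shared Core

This account rests on a few compounds, and the source may have more. Where it says the series, first, only, none or still open, it means among the compounds named here.

compound 1 `O=C(CCSc1nc2c(Cl)cccc2o1)N1CCCC1` — 97.9 mL/min/g
compound 2 `O=C(CCSc1nc2ccccc2o1)N1CCCC1` — 161 mL/min/g

Among the compounds with values here, in an ADME assay on microsomes from liver (Mus musculus) for metabolic stability, read by LC-MS, using NADPH, with a stated time of 45 min, tested at 0.5 uM (a higher number here means faster removal of the compound, a lower number slower removal), compound 2 gives 161 mL/min/g, the highest of the two numbers so far, with compound 1 nearest at 97.9 mL/min/g. Within the data shown here, the one measured step, a 1.6-fold higher number from compound 1 to compound 2 (0.22 log units; within the scatter), lies within the scatter. Compound 3 `O=C(CCSc1nc2ccc(Cl)cc2o1)N1CCCC1` differs from compound 2 by chloro in place of hydrogen on an aromatic carbon. That earlier step is the only one that bears on this change, and it removed a chloro group from the shared core while the present step adds one. Compound 3 is therefore expected to show no step beyond the scatter, a 1.3-fold lower number from compound 2 to compound 3 (0.13 log units; within the scatter), with an estimate of 120 mL/min/g and a range from 60 mL/min/g to 240 mL/min/g.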

Compound 3, intrinsic clearance in a liver preparation (reported as CLH), per the amount of preparation that the assay uses: 109 mL/min/g
For compound 3 the middle estimate is 1.1-fold (0.04 log units) above the measured one; low and high end bracket the measured number.
By their numbers in this assay, from the lowest: compounds 1, 3 and 2 (each within the scatter of the next).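

In this assay, chloro on an aromatic carbon meta to a fused ring and para to a fused ring gives a 1.5-fold lower number from compound 2 to compound 3 (0.17 log units; within the scatter), so this position, like the chloro position of compound 1, shows no change beyond the scatter. Chloro therefore has now been seen at two places on the shared core, and neither step leaves the scatter. No measured evidence bears on this result. Still open, going by these compounds, is whether a trifluoromethyl group or an amine on this same carbon would give a step beyond the scatter, and whether a longer chain elsewhere in the compound would do so.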